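Aryl amine variation on the shared core

The compounds below may be only part of what the source reports. "The series", "measured", "known", "first", "only" and "open" are said of these compounds alone.

Measured so far:
compound 1 `Cc1ccc(NC2=CC(=O)c3c(nc4n3[C@H]3OC[C@@H](O)[C@H]3OC4)C2=O)cc1C` — 1050 nM
compound 2 `O=C1C(NC2CCCCC2)=CC(=O)c2c1nc1n2[C@H]2OC[C@@H](O)[C@H]2OC1` — > 8000 nM, a limit of the assay
compound 3 `O=C1C(Nc2ccccc2F)=CC(=O)c2c1nc1n2[C@H]2OC[C@@H](O)[C@H]2OC1` — 2000 nM

In a functional assay on MGC-803 cells (Homo sapiens) for inhibition, read by sulforhodamine B assay (on this read-out lower numbers stand for stronger inhibition and higher numbers for weaker inhibition), compound 3 sits beside compound 1: the step of a 1.9-fold higher number from compound 1 to compound 3 (0.28 log units; within the scatter) stays within the scatter, so no order between the two is claimed. Compound 2 reports only a limit, (the limit of > 8000 nM in this assay, at which 1 of the 3 values shown sits). The steps of an at least 7.6-fold higher number from compound 1 to compound 2 (0.88 log units; beyond the scatter) and an at least 4.0-fold lower number from compound 2 to compound 3 (0.60 log units; beyond the scatter) leave the cyclohexyl amine well behind either aryl amine. Compound 4 `CCc1ccc(NC2=CC(=O)c3c(nc4n3[C@H]3OC[C@@H](O)[C@H]3OC4)C2=O)cc1` carries 4-ethylphenyl in place of 2-fluorophenyl on an amine nitrogen. The aryl-to-aryl step a 1.9-fold higher number from compound 1 to compound 3 (0.28 log units; within the scatter) is the one that bears on this change, and the 4-ethylphenyl of compound 4 is closer in kind to the 3,4-dimethylphenyl of compound 1 than to the 2-fluorophenyl of compound 3. A step of a 1.7-fold lower number from compound 3 to compound 4 (0.22 log units; within the scatter) is therefore expected, a modestly lower number near the edge of the scatter. Compound 4 is estimated at 1200 nM, within 600 nM to 2600 nM.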

Compound 4, half-maximal inhibitory concentration: 1110 nM
Beside the measured number, compound 4's estimate is 1.1-fold (0.03 log units) above it, and the stated range covers the measured number.
By their numbers in this assay, from the lowest: compounds 1, 4 and 3 (each within the scatter of the next). At a limit, above all of these: compound 2.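

In this assay, the steps of a 1.8-fold lower number from compound 3 to compound 4 (0.26 log units; within the scatter) and a 1.1-fold higher number from compound 1 to compound 4 (0.02 log units; within the scatter) both stay within the scatter, so a 4-ethylphenyl, a 2-fluorophenyl and a 3,4-dimethylphenyl on this amine nitrogen are not told apart. The step of an at least 7.2-fold lower number from compound 2 to compound 4 (0.85 log units; beyond the scatter) lies beyond the scatter, so the gap to the cyclohexyl amine now holds for all three aryl amines. Compound 2 gives only a limit: the limit of > 8000 nM in this assay, at which 1 of the 4 values shown sits.

Open, on these data alone, is whether a benzyl group or a pyridyl ring on this amine nitrogen would stay with the aryl amines or fall toward compound 2.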